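This account rests on a few compounds, and the source may have more. Where it says the series, first, only, none or still open, it means among the compounds named here.

Working notes on a set of four analogues sharing one core. Compound 2 `Oc1ccc(-c2cc(-c3ccc(Cl)cc3)nc(-c3ccsc3)c2)cc1` gives 4860 nM in an ADME assay on HEK293 cells (Homo sapiens) for cytotoxicity, read by CCK-8 assay and cell counting, with a stated time of 2 days (on this read-out higher numbers stand for weaker inhibition and lower numbers for stronger inhibition), the second highest of the three measured numbers. Compound 1 `Oc1ccc(-c2cc(-c3ccco3)nc(-c3ccccc3Cl)c2)cc1` gives 4310 nM, within the scatter of compound 2. Within the data shown here, compound 3 `Oc1cccc(-c2cc(-c3ccc(Cl)cc3)nc(-c3ccsc3)c2)c1` gives 11200 nM; the single one-point step measured is a 2.3-fold higher number from compound 2 to compound 3 (0.36 log units; beyond the scatter). Compound 4 `Oc1ccc(-c2cc(-c3ccc(Cl)cc3)nc(-c3ccco3)c2)cc1` differs from compound 2 by furan-2-yl in place of thiophen-3-yl on an aromatic carbon. The step from compound 2 to compound 3 concerns the hydroxyphenyl and does not bear on this change. Among the measured compounds shown here, compound 1 carries furan-2-yl, yet no one-point step links it to compound 2 or compound 4, and its value and that of compound 2 sit within the scatter. The expected step from compound 2 to compound 4 is a 1.1-fold lower number from compound 2 to compound 4 (0.02 log units; within the scatter), none beyond the scatter. For compound 4 the estimate is 4600 nM, in the range 2300 nM to 9200 nM.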

Compound 4, half-maximal inhibitory concentration: 5720 nM
Beside the measured number, compound 4's estimate is 1.2-fold (0.09 log units) below it, and the stated range covers the measured number.
By their numbers in this assay, from the lowest: compounds 1, 2, 4 and 3 (each within the scatter of the next, the first and the last beyond it).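

In this assay, furan-2-yl in place of thiophen-3-yl next to the ring nitrogen gives a 1.2-fold higher number from compound 2 to compound 4 (0.07 log units; within the scatter), so this position tolerates the exchange of one five-membered aromatic ring for the other on this read-out. Among these compounds, the chlorine shift also stays within the scatter, with a 1.3-fold higher number from compound 1 to compound 4 (0.12 log units; within the scatter), and the hydroxyphenyl step remains the only one-point change beyond it. No measured evidence is available to explain these steps. As far as these compounds go, it remains open whether an aminomethyl or carboxylic acid group at this position would give a step beyond the scatter.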